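The compounds below may be only part of what the source reports. "The series", "measured", "known", "first", "only" and "open" are said of these compounds alone.

Compound 1 `CSc1cccc(N2C(=O)CN(c3ccc(C(F)(F)F)cc3)CC2C(=O)NC2CCCC2)c1`: 10000 nM
Compound 2 `CSc1cccc(N2C(=O)CN(c3cccc(C#N)c3)CC2C(=O)NC2CCCC2)c1`: > 50000 nM (a limit)
Compound 3 `CSc1cccc(N2C(=O)CN(c3cccnc3)CC2C(=O)NC2CCCC2)c1`: > 50000 nM (a limit)
Compound 4 `O=C(NC1CCCC1)C1CN(c2ccc(C(F)(F)F)cc2)CC(=O)N1c1cnc2ccsc2c1`: not yet measured

Within the data shown here, in an ADME assay on HepG2 cells (Homo sapiens) for cytotoxicity (on this read-out lower numbers stand for higher toxicity in this test and higher numbers for lower toxicity in this test), compound 1 gives 10000 nM, the only actual number in the set. The other two values sit at the limit of > 50000 nM in this assay, at which 2 of the 3 values shown sit.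

Change to compound 4: a group of 9 heavy atoms (7 carbon, 1 nitrogen, 1 sulfur; one five-membered aromatic ring with 1 hetero atom, one six-membered aromatic ring with 1 hetero atom) in place of a group of 8 heavy atoms (7 carbon, 1 sulfur; one six-membered aromatic ring of carbon only), on an amide-type nitrogen in a ring.

The nearest measured steps are an at least 5.0-fold higher number from compound 1 to compound 2 (0.69 log units; beyond the scatter) and an at least 5.0-fold higher number from compound 1 to compound 3 (0.69 log units; beyond the scatter). Both replace the 4-(trifluoromethyl)phenyl on an amine nitrogen in a ring, and compound 4 keeps that group. Among the measured compounds shown here, no measured step changes the 3-(methylsulfanyl)phenyl, so they bear only indirectly.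

The expected step is no change at the digits printed from compound 1 to compound 4 (within the scatter), with no shift beyond the scatter expected.

For compound 4 the estimated value is 10000 nM, with an expected range of 3000 nM to 35000 nM.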

Compound 4, half-maximal cytotoxic concentration: 30000 nM
Estimate against measurement, compound 4: 3.0-fold (0.48 log units) below, and the stated range covers the measured number.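

In this assay, the change on the amide-type nitrogen in a ring gives a 3.0-fold higher number from compound 1 to compound 4 (0.48 log units; beyond the scatter) and is the first step shown at this position. The earlier steps shown here replaced only the 4-(trifluoromethyl)phenyl on the amine nitrogen, so this position also moves the read-out, with that group kept in place. Nothing measured here gives a cause for the step.

From the compounds shown here alone, it remains open whether the step follows the ring nitrogen or the added five-membered aromatic ring. A carboxylic acid or an amine on the group at this position also remains untested in the compounds shown.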